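A few compounds are considered here, and "the series" means these few. Any claim that something is new, unique, unknown or untested is made for them only; others in the source may bear on it.

Measured so far:
- compound 1, `C[C@H]1CN(c2ncc(C(=O)NCc3ccc(F)c(F)c3)cc2Cl)CCN1C1CCN(Cc2ccc(Cl)cc2)CC1`: 6 nM
- compound 2, `CC1CN(C2CCN(Cc3ccc(Cl)cc3)CC2)CCN1c1ccc(C(=O)NCc2ccc(F)c(F)c2)cn1`: 2700 nM
- compound 3, `CNC(=O)c1cnc(N2CCN(C3CCN(Cc4ccc(Cl)cc4)C(=O)C3)[C@@H](C)C2)c(Cl)c1`: 7000 nM

All three were tested in a functional assay for antagonist activity at C-X-C chemokine receptor type 3 (Homo sapiens); a higher number here means a weaker inhibitor, a lower number a stronger inhibitor. Compound 1 has the lowest number of the three, and its distance from compound 2 and from compound 3 is far beyond the scatter of this assay, so it is the strongest inhibitor of the three. Compound 3 carries a small methyl group on an amide-type nitrogen together with a second change elsewhere, and it gives 7000 nM in this assay.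

Compound 4, `CC(C)NC(=O)c1cnc(N2CCN(C3CCN(Cc4ccc(Cl)cc4)CC3)[C@@H](C)C2)c(Cl)c1`, has not yet been measured. It differs from compound 1 in one place: isopropyl in place of 3,4-difluorobenzyl on an amide-type nitrogen. Because compound 3, which also carries a small group on an amide-type nitrogen, gives 7000 nM, a weaker inhibitor than compound 1 is expected. The step from compound 1 to compound 4 in this assay is expected to be a clear rise, a 50-fold higher number from compound 1 to compound 4 (1.70 log units; beyond the scatter), beyond the scatter. The estimate for compound 4 is 300 nM, with a likely range from 50 nM to 3000 nM.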

Compound 4, half-maximal inhibitory concentration: 5 nM
For compound 4 the middle estimate is 60-fold (1.78 log units) above the measured one; the measured number lies below the stated range.
By their numbers in this assay, from the lowest: compounds 4 and 1 (each within the scatter of the next); then compound 2; then compound 3.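

Replacing 3,4-difluorobenzyl with isopropyl on the amide-type nitrogen gives, in this assay, a 1.2-fold lower number from compound 1 to compound 4 (0.08 log units; within the scatter). Going by these compounds alone, this is the first step here that differs in one place only, and it shows that the aromatic ring and both fluorines of the 3,4-difluorobenzyl group can be exchanged for a much smaller group with no difference that can be told from the scatter. No measurement shown explains why these two groups cannot be told apart.

Still open, as far as these compounds go, is whether the same holds on this nitrogen for quite different groups, such as a longer chain like n-hexyl or a chain ending in an amine or a carboxylic acid. This is also a single pair on one core, so it says nothing yet about the same exchange on other cores.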